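Thiourea to cyanoguanidine: estimating compound 4

The source may report more compounds than this note shows. Statements on the series, on what has been measured and on what is new or still open speak of the compounds shown alone.

Measured so far in a functional assay on the whole organism with Rattus norvegicus as the target, at a dose of 100 mg/kg; a lower number here means less inhibition, a higher number more inhibition at the dose given (going by the name of the read-out):
compound 1, `CC/N=C(\S)NCCCCCCn1nc(-c2ccccc2)ccc1=O`, gives -5.6%
compound 2, `CC/N=C(/NC#N)NCCCCCCn1nc(-c2ccccc2)ccc1=O`, gives 29.1%
compound 3, `C/N=C(/NC#N)NCCCn1nc(C)ccc1=O`, gives 6.8%

Compound 1 stands lowest of the three numbers in this assay, with compound 3 nearest and compound 2 furthest from it, both beyond the scatter.

Compound 4, `C/N=C(/NC#N)N(C)CCCCn1nc(-c2ccccc2)ccc1=O`, has not been measured. Compared with compound 1 it carries a group of 8 heavy atoms (4 carbon, 4 nitrogen; no ring) in place of a group of 8 heavy atoms (5 carbon, 2 nitrogen, 1 sulfur; no ring), on a saturated chain carbon, four bonds along the chain from an aromatic nitrogen. Among the compounds with values here, the one measured step that bears on this change is the one from compound 1 to compound 2, where the same kind of exchange of the sulfur-bearing group for a nitrogen-rich group gave a number 34.7 percentage points higher from compound 1 to compound 2 (beyond the scatter). Compound 4 keeps that exchange but also carries its chain and a methyl on the amine nitrogen differently from compound 2, and compound 3, the other cyanoguanidine, gives only a small number on its own core. The step for compound 4 is therefore expected to run upward from compound 1, but by less than the step to compound 2, estimated as a number 20.6 percentage points higher from compound 1 to compound 4 (beyond the scatter). Compound 4 is thus estimated to give 15% in this assay, with a likely range from -2% to 32%.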

Compound 4, a percentage reported as inhibition, in the whole organism at one dose (the size of the read-out at that dose, not a potency): 27%
Compound 4: the middle estimate sits 12 percentage points below what was measured; the measured number falls inside the stated range.
By their numbers in this assay, from the lowest: compound 1; then compound 3; then compounds 4 and 2 (each within the scatter of the next).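

The result in this assay shows that exchanging the sulfur-bearing group for the nitrile-bearing group, at the place on a saturated chain carbon, four bonds along the chain from an aromatic nitrogen, gives a number 32.6 percentage points higher from compound 1 to compound 4 (beyond the scatter) and so a large rise once more. Until now the only such rise was a number 34.7 percentage points higher from compound 1 to compound 2 (beyond the scatter) on a single chain, whereas this second step shows a large rise with a differently built chain and a methyl on the amine nitrogen; the pattern covers only these two pairs, and compound 3 goes against any wider reading, with a nitrile-bearing group on its own core and 6.8% as its number. Nothing measured here gives a reason for the rise.

The compounds shown leave open how much of the rise belongs to the nitrile-bearing group and how much to the chain or the methyl, and no pair here separates these parts. From the compounds shown here alone, it also remains open whether an amine, a carboxylic acid or a longer chain at this place would hold the number or lose it.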